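The source may hold more compounds than are shown below. What is called first, only, known or untested is meant among the compounds shown, and "the series" means these compounds.

Compound 1 `O=C1/C(=C/c2ccccc2F)CN(S(=O)(=O)c2ccccc2)C/C1=C\c1ccccc1F` gives 15900 nM in a functional assay on HepG2 cells (Homo sapiens) for cytotoxicity, read by MTT assay, with a stated time of 24 h; on this read-out lower numbers stand for stronger inhibition and higher numbers for weaker inhibition.
Compound 2 `O=C1/C(=C/c2ccccc2F)CN(S(=O)(=O)c2ccc(O[N+](=O)[O-])cc2)C/C1=C\c1ccccc1F` gives 16500 nM in this assay.
Compound 3 `O=C1/C(=C/c2ccccc2F)CN(S(=O)(=O)c2ccc(Br)cc2)C/C1=C\c1ccccc1F` gives 13700 nM in this assay.

These three compounds share one core and differ only in a single group on one aromatic ring. Compound 3 holds the lowest of the three numbers, but the steps of a 1.2-fold lower number from compound 1 to compound 3 (0.06 log units; within the scatter) and a 1.2-fold lower number from compound 2 to compound 3 (0.08 log units; within the scatter) both lie within the scatter, so the three values sit together and none can be called stronger than another.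

Compound 4 `CC(=O)Nc1ccc(S(=O)(=O)N2C/C(=C\c3ccccc3F)C(=O)/C(=C/c3ccccc3F)C2)cc1` has not yet been measured. It differs from compound 3 by acetamido in place of bromo on an aromatic carbon. The two steps that bear on this are the ones already seen at the same place: a 1.2-fold lower number from compound 1 to compound 3 (0.06 log units; within the scatter) and a 1.2-fold lower number from compound 2 to compound 3 (0.08 log units; within the scatter). Neither a bare hydrogen, a nitrooxy group nor a bromine at this position moved the number beyond the scatter. Nothing in these data suggests that an acetamido group at the same place should behave differently, so the expected step is a 1.1-fold higher number from compound 3 to compound 4 (0.04 log units; within the scatter), that is, none beyond the scatter.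

The estimate for compound 4 in this assay is therefore 15000 nM, with a range from 7000 nM to 32000 nM.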

Compound 4, half-maximal inhibitory concentration: 5200 nM
For compound 4 the middle estimate is 2.9-fold (0.46 log units) above the measured one; measured number outside the range, below it.
By their numbers in this assay, from the lowest: compound 4; then compounds 3, 1 and 2 (each within the scatter of the next).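

Going by these compounds alone, until now this position looked indifferent in this assay, yet acetamido is the first group there to move the number beyond the scatter: it gives a 2.6-fold lower number from compound 3 to compound 4 (0.42 log units; beyond the scatter) when it replaces bromo, a 3.2-fold lower number from compound 2 to compound 4 (0.50 log units; beyond the scatter) when it replaces nitrooxy and a 3.1-fold lower number from compound 1 to compound 4 (0.49 log units; beyond the scatter) when it replaces hydrogen. The position therefore does respond to what it carries, although all three steps are modest in size and hydrogen, nitrooxy and bromo remain within the scatter of one another. Acetamido is larger than bromo by its count of heavy atoms and, unlike bromo, has a hydrogen-bond donor and acceptor, but no measurement here shows whether any of these differences accounts for the stronger inhibition.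

The compounds shown leave open which part of the acetamido group matters, the amide hydrogen, the carbonyl or the group as a whole. A simple amine at this place, or a longer chain on the carbonyl, would help to separate these possibilities and show whether the number can fall further.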